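This account rests on a few compounds, and the source may have more. Where it says the series, first, only, none or still open, it means among the compounds named here.

Compound 3, `CCOC(=O)c1cnn(C)c1NC(=O)NC(C)C`, gives 77 nM in a functional assay on cells (Neutrophil, Homo sapiens) for inhibition, with a stated time of 10 min (on this read-out lower numbers stand for stronger inhibition and higher numbers for weaker inhibition), the highest of the two numbers shown there. Compound 1, `CCCC(O)Cn1ncc(C(=O)OCC)c1NC(=O)NC(C)C`, gives 20 nM in this assay, the nearest number to compound 3. Compound 2, `CCOC(=O)c1cnn(CC(C)O)c1NC(=O)Nc1cccc(F)c1`, shows in this assay only a limit of > 10 nM, not a number. Within the data shown here, the one step measured, a 3.9-fold higher number from compound 1 to compound 3 (0.59 log units; beyond the scatter), runs from compound 1 to compound 3 and replaces the 1-hydroxybutyl group with a hydrogen on the saturated chain carbon bound to an aromatic nitrogen.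

Compound 4, `CCOC(=O)c1cnn(CC(C)O)c1NC(=O)NC(C)C`, is not yet measured. It differs from compound 3 by 1-hydroxyethyl in place of hydrogen on a saturated chain carbon bound to an aromatic nitrogen; read one bond further out, the change is from methyl to 2-hydroxypropyl. The step from compound 1 to compound 3 bears directly on this change, since it removed a hydroxyalkyl group at the same place and gave a modest rise in the number. Restoring a shorter hydroxyalkyl group in compound 4 is expected to move the number back down by a modest amount, though not necessarily as far as the longer group in compound 1, so the step of a 2.6-fold lower number from compound 3 to compound 4 (0.41 log units; beyond the scatter) is estimated as a decrease beyond the scatter. Compound 4 is therefore expected to give about 30 nM, within a range from 12 nM to 80 nM, in this assay.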

Compound 4, half-maximal inhibitory concentration: 90 nM
Beside the measured number, compound 4's estimate is 3.0-fold (0.48 log units) below it; the measured number lies above the stated range.
By their numbers in this assay, from the lowest: compound 1; then compounds 3 and 4 (each within the scatter of the next).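

In this assay, the 1-hydroxyethyl group on the saturated chain carbon bound to an aromatic nitrogen gives a number within the scatter of hydrogen at that place: a 1.2-fold higher number from compound 3 to compound 4 (0.07 log units; within the scatter). A hydroxyalkyl group at this place therefore does not by itself bring the lower number seen for compound 1, as the earlier step from compound 1 to compound 3 had left possible. The step of a 4.5-fold higher number from compound 1 to compound 4 (0.65 log units; beyond the scatter) lies beyond the scatter and goes with hydrogen in place of ethyl on a saturated chain carbon, two bonds along the chain from an oxygen on a saturated carbon, so among these compounds the lower number goes with the full 1-hydroxybutyl group rather than with the hydroxyl alone.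

On these data alone, compound 2 shows only a limit, so its step to compound 4, isopropyl in place of 3-fluorophenyl on an amide-type nitrogen, cannot be read: the limit of > 10 nM in this assay, at which 1 of the 4 values shown sits. It remains open how a chain longer than that of compound 1, or an amine in place of the hydroxyl, would read in this assay.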